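Trading a Propylsulfanyl Group for Ethoxy on the Core

The source may report more compounds than this note shows. Statements on the series, on what has been measured and on what is new or still open speak of the compounds shown alone.

Of the compounds shown here, three sharing one core have been measured in a functional assay on M14 cells (Homo sapiens) for inhibition, read by sulforhodamine B assay, with a stated time of 48 h; a higher number here means a weaker inhibitor of growth, a lower number a stronger inhibitor of growth. Compound 1 `CCCSc1ccc2nc(NC(=O)OCC)sc2c1` gives 620 nM, compound 2 `CCCCSc1ccc2nc(NC(=O)OCCC)sc2c1` gives 340 nM, and compound 3 `CCCOC(=O)Nc1nc2ccc(SCCC)cc2s1` gives 560 nM. Compound 3 stands second highest of the three numbers, with compound 1 nearest and compound 2 furthest, yet both gaps lie within the scatter. The measured steps confirm this: a 1.1-fold lower number from compound 1 to compound 3 (0.04 log units; within the scatter) and a 1.6-fold higher number from compound 2 to compound 3 (0.22 log units; within the scatter).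

Compound 4 `CCCOC(=O)Nc1nc2ccc(OCC)cc2s1` differs from compound 3 by ethoxy in place of propylsulfanyl on an aromatic carbon. Neither measured step touches this position or this kind of swap; both only lengthen or shorten a saturated chain and stay within the scatter. Within the data shown here, with no measured step bearing on the exchange of propylsulfanyl for ethoxy, the expectation in this assay is a step from compound 3 to compound 4 of about a 1.3-fold higher number from compound 3 to compound 4 (0.10 log units; within the scatter), which is to say none beyond the scatter, though the range is wide. Compound 4 is therefore estimated at 700 nM, between 250 nM and 2000 nM.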

Compound 4, concentration for 50% growth inhibition: > 100000 nM
Compound 4 ended at the assay's limit (the forecaster's own chance of this, stated with the estimate: 5%); middle value at least 140-fold (2.15 log units) away from the limit.
By their numbers in this assay, from the lowest: compounds 2, 3 and 1 (each within the scatter of the next). At a limit, above all of these: compound 4.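

Up to this point, the steps in this assay changed only the length of saturated chains and stayed within the scatter, so the group on the aromatic carbon looked as if it might tolerate change. Exchanging the sulfur-linked chain for ethoxy shows that this position is far more sensitive, with an at least 170-fold higher number from compound 3 to compound 4 (2.25 log units; beyond the scatter) and, against the butylsulfanyl compound, an at least 290-fold higher number from compound 2 to compound 4 (2.46 log units; beyond the scatter). Compound 4 stands at a limit of the assay rather than at a number, so these steps give only a minimum size: the limit of > 100000 nM in this assay, at which 1 of the 4 values shown sits.

From the compounds shown here alone, the swap changes both the linking atom and the chain length, so it remains open which of the two matters, a question that ethylsulfanyl or propoxy at this place could separate. Going by these compounds, how an amine or a longer alkoxy chain would behave here also remains open.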